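The source may hold more compounds than are shown below. What is called first, only, known or untested is meant among the compounds shown, and "the series" means these compounds.

Measured so far in an assay for inhibition of Amine oxidase [flavin-containing] A (Homo sapiens), read by fluorescence and spectrophotometry, using microsomes, with stated times of 30 min and 20 min; on this read-out higher numbers stand for weaker inhibition and lower numbers for stronger inhibition:
compound 1, `CC(C)c1noc(-c2ccc(C3=NCCN3)cc2)n1`, gives 22500 nM;
compound 2, `Clc1cccc(-c2noc(-c3ccc(C4=NCCN4)cc3)n2)c1`, gives 5470 nM.

Going by the values given here, compound 2 holds the lowest of the two numbers; the single recorded step, a 4.1-fold lower number from compound 1 to compound 2 (0.61 log units; beyond the scatter), is 3-chlorophenyl in place of isopropyl on an aromatic carbon and lies beyond the scatter.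

Compound 3, `Clc1ccc(-c2noc(-c3ccc(C4=NCCN4)cc3)n2)cc1Cl`, is not yet measured. It differs from compound 2 by chloro in place of hydrogen on an aromatic carbon: on the shared core this reads 3-chlorophenyl to 3,4-dichlorophenyl, the new chloro sitting on a six-membered aromatic ring of carbon only, ortho to a chloro group and para to a large group.

Among the compounds with values here, no recorded step adds a substituent to the aryl ring, so the only bearing is indirect: the step from compound 1 to compound 2 shows that a chlorinated aryl at this position is tolerated and favoured. A second chloro is expected to move the number only little, if at all, in the same direction; for compound 3 the expected step is a 1.6-fold lower number from compound 2 to compound 3 (0.19 log units; within the scatter), within the scatter.

The estimate for compound 3 in this assay is 3500 nM, with a range of 1200 nM to 10000 nM.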

Compound 3, half-maximal inhibitory concentration: 1110 nM
The estimate for compound 3 lay 3.2-fold (0.50 log units) above the measured number; the measured number lies below the stated range.
By their numbers in this assay, from the lowest: compound 3; then compound 2; then compound 1.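

In this assay the aryl group at this position still responds to substitution after the first chloro: chloro in place of hydrogen gives a 4.9-fold lower number from compound 2 to compound 3 (0.69 log units; beyond the scatter) and so the ring itself matters here, not only the exchange of isopropyl for an aryl group. Across the whole change, 3,4-dichlorophenyl in place of isopropyl gives a 20-fold lower number from compound 1 to compound 3 (1.31 log units; beyond the scatter) and the number falls at both steps of this short run. Nothing available explains why the second chloro lowers the number.

Open, going by these compounds, is whether a chloro para to a large group would give this effect without the other chloro on the ring. Also open, on these data alone, is how a methoxy, a trifluoromethyl or an amine would read in place of the new chloro.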